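Ester in place of nitrile on the shared core

This account rests on a few compounds, and the source may have more. Where it says the series, first, only, none or still open, it means among the compounds named here.

Measured so far:
compound 1 `CS(=O)(=O)c1ccc(CNc2cc(C(F)(F)F)cc3[nH]ncc23)c([N+](=O)O)c1`: 58000 nM
compound 2 `O=[N+]([O-])c1cc(Br)c(F)cc1CNc1cc(C(F)(F)F)cc2[nH]ncc12`: > 100000 nM
compound 3 `N#Cc1cc(NCc2ccccc2[N+](=O)[O-])c2cn[nH]c2c1`: > 100000 nM

Among the measured compounds shown here, in an assay for inhibition of Indoleamine 2,3-dioxygenase 1 (Homo sapiens), with stated times of 10 min and 60 min (on this read-out lower numbers stand for stronger inhibition and higher numbers for weaker inhibition), compound 1 gives 58000 nM, the only plain number in the set. For compound 2 the readout is a limit, > 100000 nM. Compound 3 likewise returns only a limit, > 100000 nM. From the compounds shown here alone, compound 3 thus stands at the limit of > 100000 nM in this assay, at which 2 of the 3 values shown sit; its true value is unknown beyond that limit, and no comparison of size with compound 1 can be drawn from it.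

Compound 4 `COC(=O)c1cc(NCc2ccccc2[N+](=O)[O-])c2cn[nH]c2c1` is the next structure. It differs from compound 3 by methoxycarbonyl in place of cyano on an aromatic carbon. For the measured compounds named here, no pair of measured compounds differing in a single place is available, so nothing in the set shows how such a change moves this assay.

With compound 3 known only as a limit, compound 4 is expected to remain weak in this assay, estimated at 100000 nM with a range from 30000 nM to 300000 nM. The expected step is a number no higher from compound 3 to compound 4 (the limit leaves the size open), no move beyond the usual scatter, and a further limit rather than a number is the more likely outcome.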

Compound 4, half-maximal inhibitory concentration: > 100000 nM
Compound 4: only a limit was reported (the forecaster's own chance of this, stated with the estimate: 60%); the middle value sits exactly at the limit.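

Compound 3 and compound 4 both return only a limit in this assay, so no step can be read between them: the limit of > 100000 nM in this assay, at which 3 of the 4 values shown sit.

The compounds shown leave open whether methoxycarbonyl in place of cyano on an aromatic carbon moves this assay at all, or in which direction.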